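Oxadiazole sulfonamides: benzyl ring substitution and EP1 antagonism

The source may hold more compounds than are shown below. What is called first, only, known or untested is meant among the compounds shown, and "the series" means these compounds.

Measured so far:
compound 1 `CCc1ccccc1N(Cc1nnc(Cc2ccc(Cl)cc2)o1)S(=O)(=O)c1ccc(C)cc1` — 316 nM
compound 2 `Cc1ccc(S(=O)(=O)N(Cc2nnc(Cc3ccc(C(F)(F)F)cc3)o2)c2cccc(Cl)c2C)cc1` — 158 nM

In a functional assay on CHO cells for antagonist activity at prostaglandin E2 receptor EP1 subtype (Homo sapiens), read by FLIPR and calcium flux (on this read-out lower numbers stand for stronger inhibition and higher numbers for weaker inhibition), compound 2 gives 158 nM and compound 1 gives 316 nM; the gap between the two lies within the scatter, so neither is set apart from the other. Compound 3 `Cc1ccc(S(=O)(=O)N(Cc2nnc(Cc3ccc(Cl)cc3Cl)o2)c2cccc(Cl)c2C)cc1` is not yet measured. It differs from compound 2 by 2,4-dichlorophenyl in place of 4-(trifluoromethyl)phenyl on a saturated chain carbon bound to an aromatic carbon. Going by the values given here, with no single-point step measured, the step from compound 2 to compound 3 is expected to stay within the scatter, as a 1.1-fold lower number from compound 2 to compound 3 (0.02 log units; within the scatter). For compound 3 the expected value is 150 nM, between 50 nM and 500 nM.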

Compound 3, inhibition constant: 1000 nM
The estimate for compound 3 lay 6.7-fold (0.82 log units) below the measured number; the whole stated range lies below it.
By their numbers in this assay, from the lowest: compounds 2 and 1 (each within the scatter of the next); then compound 3.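

The benzyl position is not indifferent to its substituent: in this assay the change from 4-(trifluoromethyl)benzyl to 2,4-dichlorobenzyl gives a 6.3-fold higher number from compound 2 to compound 3 (0.80 log units; beyond the scatter) on an otherwise unchanged core. Going by these compounds alone, compounds 1 and 2 could not show this, as they differ in more than one place and no single-place step was available. No measurement shown here accounts for the step.

Open, going by these compounds, is whether the step belongs to one chlorine or to both. On these data alone, how a 4-methoxybenzyl or an unsubstituted benzyl group would read on the core of compound 2 also remains open.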